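Moving a Fluorine Around the Phenyl Ring

The source may hold more compounds than are shown below. What is called first, only, known or untested is meant among the compounds shown, and "the series" means these compounds.

Compound 1 `O=C1CSC(c2cccc(Cl)c2)N1CCN1CCCCC1`: 15%
Compound 2 `O=C1CSC(c2ccc(F)cc2)N1CCN1CCCCC1`: 11%

Two compounds share one core and differ only in the aryl group on a saturated ring carbon. In an ADME assay on Vero cells (Chlorocebus sabaeus) for cytotoxicity, read by neutral red uptake, tested at 3150 ug/mL (a higher number here means a weaker effect of the compound at the concentration tested, a lower number a stronger effect), compound 1 gives 15% and compound 2 gives 11%. Among the compounds with values here, the single measured step, a number 4 percentage points lower from compound 1 to compound 2 (within the scatter), shows that placing 4-fluorophenyl where 3-chlorophenyl stood left the read-out essentially unchanged, so compound 2 stands together with compound 1, its only neighbour, inside the usual scatter.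

Compound 3 `O=C1CSC(c2cccc(F)c2)N1CCN1CCCCC1` is the next member of the series: 3-fluorophenyl in place of 4-fluorophenyl on a saturated ring carbon. Within the data shown here, the only measured step that bears on this change is the one from compound 1 to compound 2, and it was small. On that basis no shift beyond the scatter is expected in this assay. The expected step is a number 2 percentage points higher from compound 2 to compound 3 (within the scatter). Compound 3 is estimated at 13%, within a range from 4% to 24%.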

Compound 3, a percentage reported as activity, at one concentration (the size of the read-out at that concentration, not a potency): 13%
Compound 3: middle estimate and measured number agree at the digits printed; the range from low to high includes it.
By their numbers in this assay, from the lowest: compounds 2, 3 and 1 (each within the scatter of the next).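

Putting 3-fluorophenyl where 4-fluorophenyl stood gives a number 2 percentage points higher from compound 2 to compound 3 (within the scatter) in this assay, so the place of the fluorine on the phenyl ring cannot be told apart within the scatter. Keeping that place and exchanging the halogen gives a number 2 percentage points lower from compound 1 to compound 3 (within the scatter) in this assay, so fluoro in place of chloro on an aromatic carbon also stays within the scatter. The earlier step changed the halogen and its place together, whereas these two steps separate them, and neither separate change lies beyond the scatter.

No measurement at hand offers an explanation for why these three compounds read alike. On these data alone, whether a different kind of group on the phenyl ring, such as a methoxy group, an amine or a carboxylic acid, would give a step beyond the scatter remains open.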